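Aryl hydrazone variation in a splenocyte cytotoxicity series

The compounds below may be only part of what the source reports. "The series", "measured", "known", "first", "only" and "open" are said of these compounds alone.

Measured so far:
compound 1, `COc1cc(/C=N/NC(=O)CCN2CCN(c3ccnc4cc(Cl)ccc34)CC2)ccc1O`: 9400 nM
compound 2, `CC(C)Oc1ccc(/C=N/NC(=O)CCN2CCN(c3ccnc4cc(Cl)ccc34)CC2)cc1`: 3600 nM

In an ADME assay on cells (Splenocyte, Mus musculus, strain BALB/c) for cytotoxicity, read by thymidine incorporation, with a stated time of 24 h (a higher number here means a weaker inhibitor, a lower number a stronger inhibitor), compound 1 gives 9400 nM and compound 2 gives 3600 nM; the step is a 2.6-fold lower number from compound 1 to compound 2 (0.42 log units; beyond the scatter). Compound 2 thus holds the lower of the two numbers. Compound 3, `COc1cc(/C=N/NC(=O)CCN2CCN(c3ccnc4cc(Cl)ccc34)CC2)ccc1OC(C)=O`, is not yet measured in this assay; its change from compound 2 is 4-acetoxy-3-methoxyphenyl in place of 4-isopropoxyphenyl on a carbon with a double bond to nitrogen. Going by the values given here, the only step bearing on this is a 2.6-fold lower number from compound 1 to compound 2 (0.42 log units; beyond the scatter). The 4-acetoxy-3-methoxyphenyl group of compound 3 resembles the 4-hydroxy-3-methoxyphenyl group of compound 1 more than the 4-isopropoxyphenyl group of compound 2, so compound 3 is expected to give a number between those of compound 1 and compound 2, an expected step of a 1.7-fold higher number from compound 2 to compound 3 (0.22 log units; within the scatter). The estimate for compound 3 is 6000 nM, expected range 2500 nM to 15000 nM.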

Compound 3, half-maximal inhibitory concentration: 15800 nM
Compound 3: the middle estimate sits 2.6-fold (0.42 log units) below what was measured; measured number outside the range, above it.
By their numbers in this assay, from the lowest: compound 2; then compounds 1 and 3 (each within the scatter of the next).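

In this assay the group on a carbon with a double bond to nitrogen moves the number upward as well as downward, with a 4.4-fold higher number from compound 2 to compound 3 (0.64 log units; beyond the scatter) reversing the earlier gain. Acetyl in place of hydrogen on an oxygen on an aromatic ring gives a 1.7-fold higher number from compound 1 to compound 3 (0.23 log units; within the scatter) and so leaves compound 3 level with compound 1, while compound 2 stands apart from both. Nothing available accounts for this difference.

Open, from the compounds shown here alone, is whether the lower number of compound 2 goes with the isopropoxy group or with the absence of the methoxy group. An unsubstituted phenyl at this place would help separate the two.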